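A few compounds are considered here, and "the series" means these few. Any claim that something is new, unique, unknown or untested is made for them only; others in the source may bear on it.

Compound 2 `C/C(=C\C(=O)Nc1ccccc1OCCCC(=O)O)c1ccc2c(ccn2C(CC(C)C)c2ccccc2)c1` holds the lower of the two numbers available in an assay on Prostate gland for inhibition of steroid 5-alpha-reductase (Rattus norvegicus) (on this read-out higher numbers stand for weaker inhibition and lower numbers for stronger inhibition), where compound 2 gives 6.3 nM; compound 1 `CCC(c1ccccc1)n1ccc2cc(/C(C)=C/C(=O)Nc3ccccc3OCCCC(=O)O)ccc21` gives 19 nM. Among the compounds with values here, the only measured step, a 3.0-fold lower number from compound 1 to compound 2 (0.48 log units; beyond the scatter), concerns a different exchange on the same saturated chain carbon. Compound 3 `C/C(=C\C(=O)Nc1ccccc1OCCCC(=O)O)c1ccc2c(ccn2C(c2ccccc2)c2ccccn2)c1` differs from compound 2 by pyridin-2-yl in place of isobutyl on a saturated chain carbon bound to an aromatic carbon and an aromatic nitrogen. Within the data shown here, no measured step bears directly on this exchange, so compound 3 is expected to show a 1.6-fold higher number from compound 2 to compound 3 (0.20 log units; within the scatter), with the direction uncertain. Compound 3 is therefore estimated at 10 nM, within a range from 2.5 nM to 40 nM.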

Compound 3, half-maximal inhibitory concentration: 37 nM
For compound 3 the middle estimate is 3.7-fold (0.57 log units) below the measured one; the measured number falls inside the stated range.
By their numbers in this assay, from the lowest: compound 2; then compounds 1 and 3 (each within the scatter of the next).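

The earlier compounds shown here carried only saturated chains on this carbon, whereas compound 3 places pyridin-2-yl there, bringing a six-membered aromatic ring and a hydrogen-bond acceptor. In this assay pyridin-2-yl in place of isobutyl gives a 5.9-fold higher number from compound 2 to compound 3 (0.77 log units; beyond the scatter) and pyridin-2-yl in place of ethyl gives a 1.9-fold higher number from compound 1 to compound 3 (0.29 log units; within the scatter) so the exchange loses ground against isobutyl only. The ranking at this position therefore depends on the group being replaced. On these data alone, whether a second phenyl or a hexyl chain on this carbon would match isobutyl remains open. The data shown offer no measurement that explains these differences.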